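The source may hold more compounds than are shown below. What is called first, only, known or untested is meant among the compounds shown, and "the series" means these compounds.

Compound 1 `CN(C)c1cc(-c2cc(N3C[C@H](O)[C@@H](O)C3)ccc2O)nc(N)n1`: > 10000 nM, a limit
Compound 2 `Nc1nc(-c2cc(N3C[C@H](O)[C@@H](O)C3)ccc2O)cc(C2CCCNC2)n1`: > 10000 nM, a limit

In a functional assay on HCT-116 cells (Homo sapiens) for cytotoxicity, with a stated time of 48 h (on this read-out lower numbers stand for stronger inhibition of growth and higher numbers for weaker inhibition of growth), compound 2 gives > 10000 nM, which is a limit and not a number. Both measured compounds stand at the same point: the limit of > 10000 nM in this assay, at which 2 of the 2 values shown sit. Compound 3 `CCc1cc(-c2cc(N3C[C@H](O)[C@@H](O)C3)ccc2O)nc(N)n1` alters compound 2 at one place, with ethyl in place of piperidin-3-yl on an aromatic carbon. Going by the values given here, the only measured step at this place is a step that the two limits leave unreadable from compound 1 to compound 2, so it offers no size to carry over. From the compounds shown here alone, no step beyond the scatter is therefore expected, and its direction stays open. The estimate is a step that the limit leaves unreadable from compound 2 to compound 3. Compound 3 is expected near 12000 nM, with an estimated range of 4000 nM to 30000 nM.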

Compound 3, concentration for 50% growth inhibition: 1000 nM
For compound 3 the middle estimate is 12-fold (1.08 log units) above the measured one; the whole stated range lies above it.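

Ethyl at this position brings the first readable growth inhibition of the series: in this assay, replacing piperidin-3-yl gives an at least 10-fold lower number from compound 2 to compound 3 (1.00 log units; beyond the scatter), and replacing dimethylamino gives an at least 10-fold lower number from compound 1 to compound 3 (1.00 log units; beyond the scatter). So this position can change the read-out, although the step between compound 1 and compound 2 cannot be read, as both values are limits.

Ethyl is the only group here that gives a number, so it stays open how methyl or a longer chain such as propyl would behave. From the compounds shown here alone, the full size of both steps also stays open.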